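The compounds below may be only part of what the source reports. "The series", "measured", "known", "first", "only" and "open" are said of these compounds alone.

Working notes on the series, where the aryl group on the shared core varies. In a functional assay on DU-145 cells (Homo sapiens) for inhibition, read by trypan blue exclusion, with a stated time of 96 h (a higher number here means a weaker inhibitor of growth, a lower number a stronger inhibitor of growth), compound 3 `COc1ccccc1/C=C(/Sc1ccc(C)cc1)C(=O)c1ccc(Cl)cc1` gives 25000 nM, the higher of the two actual numbers. Compound 2 `COc1ccc(/C=C(/Sc2ccc(C)cc2)C(=O)c2ccc(Cl)cc2)cc1O` gives 1000 nM. Compound 1 `Cc1ccc(S/C(=C/c2c(O)cc(O)cc2O)C(=O)c2ccc(Cl)cc2)cc1` reads > 100000 nM, which is a limit of the assay and not a number. Measured against that limit, the changes are an at least 100-fold lower number from compound 1 to compound 2 (2.00 log units; beyond the scatter) and an at least 4.0-fold lower number from compound 1 to compound 3 (0.60 log units; beyond the scatter).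

Next in line is compound 4 `COc1ccc(/C=C(/Sc2ccc(C)cc2)C(=O)c2ccc(Cl)cc2)cc1`, related to compound 3 by 4-methoxyphenyl in place of 2-methoxyphenyl on a double-bonded chain carbon bound to a double-bonded chain carbon: 4-methoxyphenyl in place of 2-methoxyphenyl, on a double-bonded chain carbon bound to a double-bonded chain carbon. Going by the values given here, no measured step makes this exact swap. The closest evidence is a 25-fold higher number from compound 2 to compound 3 (1.40 log units; beyond the scatter), the step that brings in 2-methoxyphenyl. Removing that group is expected to recover part of this large step, though not all of it, so the number in this assay should fall moderately. The expected step is a 5.0-fold lower number from compound 3 to compound 4 (0.70 log units; beyond the scatter). For compound 4 the estimate is 5000 nM, with an expected range from 1200 nM to 20000 nM.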

Compound 4, concentration for 50% growth inhibition: 1000 nM
For compound 4 the middle estimate is 5.0-fold (0.70 log units) above the measured one, and the stated range ends above it.
By their numbers in this assay, from the lowest: compounds 2 and 4 (each within the scatter of the next); then compound 3. At a limit, above all of these: compound 1.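

On a double-bonded chain carbon bound to a double-bonded chain carbon, 4-methoxyphenyl in place of 2-methoxyphenyl gives a 25-fold lower number from compound 3 to compound 4 (1.40 log units; beyond the scatter) in this assay, so with the same atoms, how they are joined in this aryl group alone separates these two compounds. Hydrogen in place of hydroxy on an aromatic carbon gives no change at the digits printed from compound 2 to compound 4 (within the scatter), so the hydroxy of compound 2 is not needed for a number at this level. Compound 1 is held at a limit of the assay, so an at least 100-fold lower number from compound 1 to compound 4 (2.00 log units; beyond the scatter) is a bound and not a measured size: the limit of > 100000 nM in this assay, at which 1 of the 4 values shown sits.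

The compounds shown leave open how 4-ethoxyphenyl, 4-aminophenyl or 4-carboxyphenyl would read in this place. They also leave open whether the gap between 4-methoxyphenyl and 2-methoxyphenyl holds when other parts of the shared core change.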